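From trifluoromethyl to methyl on the aromatic ring

The source may hold more compounds than are shown below. What is called first, only, known or untested is meant among the compounds shown, and "the series" means these compounds.

Compound 1 `COc1cc(/C=C/C(=O)/C=C/C2=C(C)CCCC2(C)C)ccc1O` gives 21300 nM
Compound 2 `CC1=CCCC(C)(C)C1/C=C/C(=O)/C=C/c1cccc(C(F)(F)F)c1` gives 5200 nM
Compound 3 `CC1=CCCC(C)(C)C1/C=C/C(=O)/C=C/c1cc(C(F)(F)F)ccc1F` gives 3100 nM

All three figures come from a functional assay on PC-3 cells (Homo sapiens) for cytotoxicity, read by MTT assay, with a stated time of 72 h (a lower number here means a stronger inhibitor, a higher number a weaker inhibitor), and can be compared directly. Compound 2 stands within the scatter of compound 3, and its number is lower than that of compound 1.

Compound 4 `CC1=CCCC(C)(C)C1/C=C/C(=O)/C=C/c1cccc(C)c1` has not yet been measured. Among the compounds with values here, it differs from compound 2 in one place, with methyl in place of trifluoromethyl on an aromatic carbon as the only change.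

Within the data shown here, no measured step makes this exact swap. The closest evidence is a different change on the same aromatic ring, fluoro in place of hydrogen. Among the measured compounds shown here, with a 1.7-fold lower number from compound 2 to compound 3 (0.22 log units; within the scatter) as the only measured step of this kind, no step beyond the scatter is expected for compound 4 in this assay although a single step is thin evidence. The estimated step is a 1.3-fold higher number from compound 2 to compound 4 (0.10 log units; within the scatter) and it is expected to stay small. Compound 4 is estimated at 6500 nM with an expected range of 2600 nM to 16000 nM for this measurement.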

Compound 4, half-maximal inhibitory concentration: 5900 nM
Compound 4: middle estimate off by 1.1-fold (0.04 log units), on the high side; measured number inside the range.
By their numbers in this assay, from the lowest: compounds 3, 2 and 4 (each within the scatter of the next); then compound 1.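

In this assay the swap of trifluoromethyl for methyl on this aromatic carbon, meta to a large group, gives a 1.1-fold higher number from compound 2 to compound 4 (0.05 log units; within the scatter) and so leaves the two compounds indistinguishable. The earlier compounds shown here showed only a fluoro added elsewhere on the ring; this step shows that the group at this position can go from 4 heavy atoms to 1, losing all its fluorine, with no change beyond the scatter. Nothing measured here accounts for this result.

Methyl and trifluoromethyl alone say little about how an amine, a carboxylic acid or a longer alkyl chain would fare at this carbon. Also open, going by these compounds, is whether the same swap would give a similar result on the ring of compound 3, which also carries a fluoro.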